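Methyl at a Second Site on a Piperazine Acetamide

This account rests on a few compounds, and the source may have more. Where it says the series, first, only, none or still open, it means among the compounds named here.

Measured so far:
Compound 1 `Cn1c(-c2ccc(NC(=O)CSc3nc4ccccc4o3)cc2)nc(-c2ccccc2)c1-c1ccccc1` gives 71.5% in a functional assay on MCF7 cells (Homo sapiens) for cytotoxicity, read by MTT assay, with a stated time of 24 h, tested at 32 ug/mL; on this read-out higher numbers stand for a stronger effect at the one concentration tested and lower numbers for a weaker effect.
Compound 2 `Cc1ccc2oc(SCC(=O)Nc3ccc(-c4nc(-c5ccccc5)c(-c5ccccc5)n4C)cc3)nc2c1` gives 57.7% in this assay.
Compound 3 `Cn1c(-c2ccc(NC(=O)CN3CCN(Cc4ccccc4)CC3)cc2)nc(-c2ccccc2)c1-c1ccccc1` gives 33.6% in this assay.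

From compound 1 to compound 2 the change is methyl in place of hydrogen on an aromatic carbon, placed on an aromatic carbon of a six-membered aromatic ring of carbon only, part of a fused system of two rings, meta and para to a fused ring; it produced a number 13.8 percentage points lower from compound 1 to compound 2 (beyond the scatter). The difference between the core of compound 1 and the core of compound 3 is not broken down here. Compound 4 `Cc1ccc(CN2CCN(CC(=O)Nc3ccc(-c4nc(-c5ccccc5)c(-c5ccccc5)n4C)cc3)CC2)cc1` has yet to be measured. It differs from compound 3 by methyl in place of hydrogen on an aromatic carbon, here on a six-membered aromatic ring of carbon only, para to a large group, so the change is the same kind of change rather than the same. Because the earlier step was a number 13.8 percentage points lower from compound 1 to compound 2 (beyond the scatter), a modest lowering is expected, read as a number 8.6 percentage points lower from compound 3 to compound 4 (within the scatter). Compound 4 is therefore estimated at 25%, between 10% and 45%.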

Compound 4, a percentage reported as activity, at one concentration (the size of the read-out at that concentration, not a potency): 31.5%
For compound 4 the middle estimate is 6.5 percentage points below the measured one; the measured number falls inside the stated range.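

In this assay, methyl in place of hydrogen on an aromatic carbon, which turns benzyl into 4-methylbenzyl here, gave a number 2.1 percentage points lower from compound 3 to compound 4 (within the scatter). Set beside the same kind of change on the core of compound 1, the two steps cannot be told apart: the same change on two cores in this assay, a number 13.8 percentage points lower (beyond the scatter) from compound 1 to compound 2 and a number 2.1 percentage points lower (within the scatter) from compound 3 to compound 4, 11.7 percentage points apart, within the scatter of two such steps. Among these compounds, this agrees with the change carrying from one core to the other, but it does not establish that it does: only two steps are available, one of them lies within the scatter, and the methyl sits on a different ring in each.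

The compounds shown leave open how a chlorine, a methoxy or a carboxylic acid would behave at that place. They also leave open whether a longer chain in place of the benzyl group would alter the read-out.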